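Aryl replacement on the carbonyl carbon of the shared core

The compounds below may be only part of what the source reports. "The series", "measured", "known", "first", "only" and "open" are said of these compounds alone.

Measured so far in a functional assay on HepG2 cells (Homo sapiens) for cytotoxicity, read by MTT assay, with a stated time of 48 h; a higher number here means a weaker inhibitor, a lower number a stronger inhibitor:
compound 1 `COc1cc(-c2nnc3n2NC(c2ccco2)C(C(=O)c2cccs2)S3)cc(OC)c1OC`: 64100 nM
compound 2 `COc1cc(-c2nnc3n2NC(c2ccco2)C(C(=O)c2ccc(F)cc2)S3)cc(OC)c1OC`: > 100000 nM, which is a limit of the assay and not a number
compound 3 `COc1cc(-c2nnc3n2NC(c2ccco2)C(C(=O)c2ccc(O)cc2)S3)cc(OC)c1OC`: > 100000 nM, which is a limit of the assay and not a number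

Going by the values given here, compound 1 holds the only number in the set; the two further values sit at the limit of > 100000 nM in this assay, at which 2 of the 3 values shown sit. From compound 1, 4-fluorophenyl in place of thiophen-2-yl on a carbonyl carbon gives an at least 1.5-fold higher number from compound 1 to compound 2 (0.19 log units; that floor lies within the scatter), and 4-hydroxyphenyl in place of thiophen-2-yl on a carbonyl carbon gives an at least 1.5-fold higher number from compound 1 to compound 3 (0.19 log units; that floor lies within the scatter). Between the two limits, hydroxy in place of fluoro on an aromatic carbon is a step that the two limits leave unreadable from compound 2 to compound 3.

Compound 4 `COc1cc(-c2nnc3n2NC(c2ccco2)C(C(=O)c2ccc([N+](=O)[O-])cc2)S3)cc(OC)c1OC` is not yet measured. It differs from compound 1 in that (4-nitrophenyl in place of thiophen-2-yl on a carbonyl carbon). Among the compounds with values here, both measured changes that put a substituted phenyl in place of thiophen-2-yl on the carbonyl carbon moved the value from the one number up to the limit, so a step of the same direction is expected here, a 1.9-fold higher number from compound 1 to compound 4 (0.27 log units; within the scatter), with a fair chance that only a limit is reported. Compound 4 is therefore estimated at 120000 nM, within 50000 nM to 300000 nM.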

Compound 4, half-maximal inhibitory concentration: 87800 nM
For compound 4 the middle estimate is 1.4-fold (0.14 log units) above the measured one, and the stated range covers the measured number.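

In this assay, 4-nitrophenyl on the carbonyl carbon gives a readable number, so a substituted phenyl in place of thiophen-2-yl does not always end at the limit; the step itself is a 1.4-fold higher number from compound 1 to compound 4 (0.14 log units; within the scatter), which leaves the two groups unseparated. Against the other two phenyl compounds the readable floors are an at least 1.1-fold lower number from compound 3 to compound 4 (0.05 log units; that floor lies within the scatter) and an at least 1.1-fold lower number from compound 2 to compound 4 (0.05 log units; that floor lies within the scatter), so nitro cannot be ordered against hydroxy or fluoro on the aromatic carbon. Compound 2 and compound 3 each remain at a limit of the assay, not a number: the limit of > 100000 nM in this assay, at which 2 of the 4 values shown sit.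

Compound 1 gives 64100 nM. Still open, as far as these compounds go, is whether any group on this carbonyl carbon moves the number away from that of compound 1 by more than the scatter. A 4-aminophenyl group, a 4-carboxyphenyl group or a saturated alkyl chain there would test this.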